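Working notes on the hydroxamate series: cap exchange

A few compounds are considered here, and "the series" means these few. Any claim that something is new, unique, unknown or untested is made for them only; others in the source may bear on it.

Going by the values given here, compound 2 `CN(C)c1ccc(C(=O)NC(CCCCCC(=O)NO)C(=O)NCc2ccccc2)cc1` stands lowest of the two numbers measured so far: in a functional assay on MM96L cells (Homo sapiens) for antiproliferative activity (a higher number here means a weaker inhibitor, a lower number a stronger inhibitor), compound 2 gives 130 nM. Its nearest neighbour is compound 1 `CN(C)c1ccc(C(=O)N[C@H](CCCCCC(=O)NO)C(=O)NCc2ccccc2)cc1`, which in this assay gives 160 nM. Among the compounds with values here, the only measured step, a 1.2-fold lower number from compound 1 to compound 2 (0.09 log units; within the scatter), rests on nothing more than the fact that one of compounds 1 and 2 is drawn with a defined configuration and the other without, at the place where they differ, and it falls within the scatter.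

Compound 3 `O=C(CCCCCC(NC(=O)c1cccnc1)C(=O)NCc1ccccc1)NO` is the next compound to be measured. It differs from compound 2 by pyridin-3-yl in place of 4-(dimethylamino)phenyl on a carbonyl carbon. Within the data shown here, no measured step touches this carbonyl carbon or its aryl group; the one step available, a 1.2-fold lower number from compound 1 to compound 2 (0.09 log units; within the scatter), concerns only a stereocentre on the chain and does not bear on the cap exchange. The expectation therefore cannot lean on any measured direction, and the step of a 1.7-fold higher number from compound 2 to compound 3 (0.23 log units; within the scatter) is estimated as a modest one, with a wide range either way. In this assay compound 3 is expected to give 220 nM, with the estimate spanning 60 nM to 800 nM.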

Compound 3, half-maximal inhibitory concentration: 9500 nM
Beside the measured number, compound 3's estimate is 43-fold (1.64 log units) below it, outside the stated range (above it).
By their numbers in this assay, from the lowest: compounds 2 and 1 (each within the scatter of the next); then compound 3.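

Going by these compounds alone, the cap is far from a silent position: pyridin-3-yl in place of 4-(dimethylamino)phenyl on a carbonyl carbon gives a 73-fold higher number from compound 2 to compound 3 (1.86 log units; beyond the scatter) in this assay and thus the first step beyond the scatter, whereas the only earlier step, a matter of how a chain stereocentre is drawn, stayed within it. The two groups carry no net charge and the same counts of hydrogen-bond donors and acceptors, so those counts do not separate them; what differs is the number of heavy atoms, the hetero atom in the ring and the presence of the dimethylamino group. Within the data shown here, the one available fact about these compounds concerns only the drawn configuration and says nothing on why this exchange moves the number so far.

A single exchange changes the ring and removes the dimethylamino group together, so the compounds shown do not tell which of the two carries the step. A plain phenyl group on the same carbonyl carbon would separate them, and a 4-methoxyphenyl group would show whether a dimethylamino group is needed at all.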